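This account rests on a few compounds, and the source may have more. Where it says the series, first, only, none or still open, it means among the compounds named here.

Measured compounds:
- compound 1, `COc1ccc(S(=O)(=O)Nc2ccccc2CCc2ccc(C(=O)Nc3ccccc3N)cc2)cc1`, 23 nM in a functional assay on KB cells (Homo sapiens) for antiproliferative activity, read by sulforhodamine B assay, with a stated time of 48 h; a lower number here means a stronger inhibitor of growth, a higher number a weaker inhibitor of growth
- compound 2, `Nc1ccccc1NC(=O)c1ccc(CCc2ccccc2NS(=O)(=O)c2ccc(Cl)cc2)cc1`, 448 nM in this assay

Within the data shown here, compound 1 gives the lowest of the two numbers in this assay; the only other measured compound, compound 2, lies at a 19-fold higher number from compound 1 to compound 2 (1.29 log units; beyond the scatter), a change made by cyano in place of methoxy on an aromatic carbon being absent there and chloro in place of methoxy on an aromatic carbon instead.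

Compound 3, `N#Cc1ccc(S(=O)(=O)Nc2ccccc2CCc2ccc(C(=O)Nc3ccccc3N)cc2)cc1`, is not yet measured. It differs from compound 1 by cyano in place of methoxy on an aromatic carbon. Among the measured compounds shown here, the one step that bears on it is the exchange at the same aromatic carbon, a 19-fold higher number from compound 1 to compound 2 (1.29 log units; beyond the scatter), which was large and went toward weaker inhibition. For the measured compounds named here, only that single step is available, and cyano is a different group from chloro, so the size is uncertain, but the direction is taken from it: a step toward a higher number, beyond the scatter, is expected for compound 3, a 6.5-fold higher number from compound 1 to compound 3 (0.81 log units; beyond the scatter). Compound 3 is therefore estimated at 150 nM in this assay, with a range from 40 nM to 600 nM.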

Compound 3, concentration for 50% growth inhibition: 790 nM
The estimate for compound 3 lay 5.3-fold (0.72 log units) below the measured number, outside the stated range (above it).
By their numbers in this assay, from the lowest: compound 1; then compounds 2 and 3 (each within the scatter of the next).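

In this assay, the methoxy place now has two replacements, and the second also costs much (cyano in place of methoxy: a 34-fold higher number from compound 1 to compound 3 (1.54 log units; beyond the scatter)), so the loss seen with chloro is not particular to chloro. The two replacements are not separated from each other (a 1.8-fold higher number from compound 2 to compound 3 (0.25 log units; within the scatter)), and of the three groups at this place, only methoxy gives a low number. The data shown offer no explanation for why methoxy stands apart from chloro and cyano.

Open, as far as these compounds go, is whether methoxy is alone in this, or whether an amine, a hydroxyl, a methyl or a longer alkoxy chain at the same place would give a similarly low number. Also open, from the compounds shown here alone, is how methoxy would fare on another carbon of that ring.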